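The source may hold more compounds than are shown below. What is called first, only, known or untested is meant among the compounds shown, and "the series" means these compounds.

Working notes on the series.

Compound 1 `CC(C(=O)NCc1ccc(C(F)(F)F)cc1N1CCCC1)c1ccc(NS(C)(=O)=O)c(F)c1` carries a pyrrolidin-1-yl group on the aromatic carbon; compound 2 `CC(C(=O)NCc1ccc(C(F)(F)F)cc1N1CCC(C)(C)CC1)c1ccc(NS(C)(=O)=O)c(F)c1` carries 4,4-dimethylpiperidin-1-yl at the same place. In an assay on CHO cells for antagonist activity at transient receptor potential cation channel subfamily V member 1 (Homo sapiens), read by FLIPR (on this read-out lower numbers stand for stronger inhibition and higher numbers for weaker inhibition), compound 1 gives 2.3 nM. In this assay compound 2 gives 1.3 nM. Among the measured compounds shown here, the one step measured so far, a 1.8-fold lower number from compound 1 to compound 2 (0.25 log units; within the scatter), is within the scatter, so the two numbers cannot be told apart, and compound 2 stands at a value that is not separated from compound 1.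

Compound 3 `CC(C(=O)NCc1ccc(C(F)(F)F)cc1N1CCC(C(F)(F)F)CC1)c1ccc(NS(C)(=O)=O)c(F)c1` is not yet measured. The change from compound 2 is 4-(trifluoromethyl)piperidin-1-yl in place of 4,4-dimethylpiperidin-1-yl on an aromatic carbon. It keeps the six-membered non-aromatic ring with one hetero atom and exchanges the two methyl groups at its far position for a single trifluoromethyl group. For the measured compounds named here, the only step that bears on this place, a 1.8-fold lower number from compound 1 to compound 2 (0.25 log units; within the scatter), was within the scatter even though it changed the ring itself, so no step beyond the scatter is expected in this assay for a change that keeps the ring and alters only its substituent.

Compound 3 is therefore expected to give 1.8 nM, with a range of 0.6 nM to 6 nM, meaning an expected step of a 1.4-fold higher number from compound 2 to compound 3 (0.14 log units; within the scatter).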

Compound 3, inhibition constant: 0.4 nM
For compound 3 the middle estimate is 4.5-fold (0.65 log units) above the measured one, and the stated range ends above it.
By their numbers in this assay, from the lowest: compound 3; then compounds 2 and 1 (each within the scatter of the next).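

At this place, on an aromatic carbon ortho to a large group, the substituent on the six-membered ring matters more than the earlier pair showed: in this assay the exchange of 4,4-dimethylpiperidin-1-yl for 4-(trifluoromethyl)piperidin-1-yl gives a 3.3-fold lower number from compound 2 to compound 3 (0.51 log units; beyond the scatter) with the ring itself unchanged. Compound 3 is also separated from the pyrrolidin-1-yl analogue, with a 5.8-fold lower number from compound 1 to compound 3 (0.76 log units; beyond the scatter) where compound 2 stayed within the scatter of compound 1, so a change of substituent alone here moves the number beyond the scatter, though only modestly. Nothing available on these compounds accounts for the difference between the trifluoromethyl group and the two methyl groups.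

From the compounds shown here alone, it remains open whether the lower number depends on the trifluoromethyl group itself or would also appear with a single methyl, a 4,4-difluoro pair or a nitrile at the far position of the same piperidine ring. Also open, going by these compounds, is how far this place tolerates a morpholine, an open-chain amine such as diethylamino, or a ring bearing a hydroxyl or carboxylic acid.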